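Thiourea-linked quinazoline sulfonamides: swapping the anilino aryl

This account rests on a few compounds, and the source may have more. Where it says the series, first, only, none or still open, it means among the compounds named here.

Of the compounds shown here, three have been tested in a functional assay on NCI-H1975 cells (Homo sapiens) for antiproliferative activity, read by MTT assay, with a stated time of 72 h; on this read-out higher numbers stand for weaker inhibition and lower numbers for stronger inhibition. Compound 1 `COc1cc2ncnc(Nc3ccc(F)c(Cl)c3)c2cc1OCCCCC(=O)Nc1ccc(S(N)(=O)=O)cc1` gives 35600 nM. For the measured compounds named here, compound 2 `COc1cc2ncnc(Nc3ccc(OC(F)(F)F)cc3)c2cc1OCCCCC(=O)Nc1ccc(S(N)(=O)=O)cc1` gives 8770 nM, and the only single-point step among them, a 4.1-fold lower number from compound 1 to compound 2 (0.61 log units; beyond the scatter), is the one change of the aryl on the nitrogen that has been measured. Compound 3 `C#Cc1cccc(Nc2ncnc3ccc(NC(=S)Nc4ccc(S(N)(=O)=O)cc4)cc23)c1` gives 13400 nM; its number lies between those of compound 2 and compound 1, close to that of compound 2 and further from that of compound 1.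

Compound 4 `NS(=O)(=O)c1ccc(NC(=S)Nc2ccc3ncnc(Nc4ccc(C(F)(F)F)cc4)c3c2)cc1` has not yet been measured. It differs from compound 3 in one place: 4-(trifluoromethyl)phenyl in place of 3-ethynylphenyl on a nitrogen on an aromatic ring. The step from compound 1 to compound 2 concerns the same position but a different pair of groups and a different linker, so it offers only a loose guide; it showed that a fluorinated aryl at this nitrogen can give a lower number. Going by the values given here, with no closer precedent, compound 4 is expected to sit near compound 3, with a step of a 1.1-fold higher number from compound 3 to compound 4 (0.05 log units; within the scatter) that may well fall within the scatter. The estimated value for compound 4 in this assay is 15000 nM, in a range from 5000 nM to 45000 nM.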

Compound 4, half-maximal inhibitory concentration: 17100 nM
For compound 4 the middle estimate is 1.1-fold (0.06 log units) below the measured one; measured number inside the range.
By their numbers in this assay, from the lowest: compounds 2, 3 and 4 (each within the scatter of the next); then compound 1.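

Putting 4-(trifluoromethyl)phenyl in place of 3-ethynylphenyl on the nitrogen gives a 1.3-fold higher number from compound 3 to compound 4 (0.11 log units; within the scatter) in this assay, so on this read-out the two aryl groups cannot be told apart with the thiourea linker. For the compounds shown here, the one earlier step at this nitrogen, a 4.1-fold lower number from compound 1 to compound 2 (0.61 log units; beyond the scatter), came with the other linker and lay beyond the scatter, whereas this change shows that an ethynyl-bearing aryl and a fluorinated one can be exchanged here with no difference the assay resolves. Nothing at hand accounts for this result.

On these data alone, it remains open whether an aryl carrying an amine or a carboxylic acid on this nitrogen would move the number beyond the scatter with the thiourea linker. As far as these compounds go, no single aryl appears here with both linkers, so the effect of the linker itself also stays unknown.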